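Swapping a Halogen on the Methoxyphenyl Arm

A few compounds are considered here, and "the series" means these few. Any claim that something is new, unique, unknown or untested is made for them only; others in the source may bear on it.

Two measured compounds share one core and differ only in the group attached to a nitrogen on an aromatic ring. Compound 1 `COc1cc(NC(=O)Nc2cc(Nc3ccc(C(C)(C)C)cc3)ncn2)cc(OC)c1` carries a 4-(tert-butyl)phenyl there, and compound 2 `COc1cc(NC(=O)Nc2cc(Nc3cc(F)ccc3OC)ncn2)cc(OC)c1` a 5-fluoro-2-methoxyphenyl. In a functional assay on NCI-H520 cells (Homo sapiens) for inhibition, read by MTT assay, with a stated time of 48 h, tested at 10 uM (a lower number here means less inhibition, a higher number more inhibition at the concentration tested (going by the name of the read-out)), compound 1 gives 17.5%, while compound 2 gives 38%. Going by the values given here, that exchange is the only measured step, a number 20.5 percentage points higher from compound 1 to compound 2 (beyond the scatter), so compound 2 stands highest of the two numbers, with compound 1 as its only neighbour.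

Compound 3 `COc1cc(NC(=O)Nc2cc(Nc3cc(Br)ccc3OC)ncn2)cc(OC)c1` differs from compound 2 in a single place: bromo in place of fluoro on an aromatic carbon. Among the compounds with values here, the one measured step replaced the whole aromatic group on that nitrogen, not one halogen for another, so it does not bear directly on this smaller change, and the data hold nothing else on a bromo against a fluoro at this spot. Without such a guide, the step from compound 2 is expected to be a number 2 percentage points higher from compound 2 to compound 3 (within the scatter), nothing beyond the scatter. Compound 3 is therefore estimated at 40% in this assay, with a likely range from 20% to 60%.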

Compound 3, a percentage reported as inhibition, at one concentration (the size of the read-out at that concentration, not a potency): 43.5%
Compound 3: the middle estimate sits 3.5 percentage points below what was measured; the range from low to high includes it.
By their numbers in this assay, from the lowest: compound 1; then compounds 2 and 3 (each within the scatter of the next).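

In this assay, the fluoro on this ring can give way to a bromo, a much larger atom, with no change that can be told from the usual scatter: there is a number 5.5 percentage points higher from compound 2 to compound 3 (within the scatter), so the two halogens cannot be ranked at this place, para to a methoxy group. The advantage over the 4-(tert-butyl)phenyl group seen earlier with the fluoro compound also appears with the bromo, as the exchange gives a number 26 percentage points higher from compound 1 to compound 3 (beyond the scatter), which means it does not depend on fluoro alone. Nothing available explains either result.

On these data alone, what remains open is whether any halogen is needed at this place, since a plain hydrogen, a chloro or an amine there would test that directly, and whether the methoxy group on the same ring contributes to the difference from compound 1. All these numbers also come from one concentration, so they describe how much inhibition appears at that dose and leave the potency of compound 2 and compound 3 unknown.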